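Swapping the sulfonyl aryl group in a quinoline sulfone

The compounds below may be only part of what the source reports. "The series", "measured", "known", "first", "only" and "open" are said of these compounds alone.

Among the measured compounds shown here, compound 1 `COc1ccc(-c2c(S(=O)(=O)c3ccc(F)c(F)c3)cnc3cc(F)ccc23)cc1` is measured in an ADME assay on microsomes from liver (Homo sapiens) for metabolic stability, tested at 2.5 uM (on this read-out higher numbers stand for fast clearance and lower numbers for slow clearance), and gives 1.1 mL/min, which places it second highest among the three compounds measured so far. Compound 3 `COc1cccc(-c2c(S(=O)(=O)c3ccc(C)c(F)c3)cnc3c(F)cccc23)c1` gives 4.02 mL/min and thus clears faster, while compound 2 `O=S(=O)(c1ccc(F)c(F)c1)c1cnc2cc(F)ccc2c1-c1ccc(Cl)cc1` gives 0.01 mL/min and clears far more slowly. For the measured compounds named here, the only step between two compounds differing in a single place is a 110-fold lower number from compound 1 to compound 2 (2.04 log units; beyond the scatter), which involves a change on the other aromatic ring, not the one attached to the sulfonyl sulfur.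

Compound 4 `COc1ccc(-c2c(S(=O)(=O)c3cc(Cl)cc(Cl)c3)cnc3cc(F)ccc23)cc1` differs from compound 1 by 3,5-dichlorophenyl in place of 3,4-difluorophenyl on a sulfonyl sulfur. Going by the values given here, no measured step touches the aryl group on the sulfonyl sulfur, so the measured steps give no direct guidance on the direction or size of the change in this assay. The estimate therefore stays close to the value of compound 1, with a wide range. Compound 4 is expected to give 1.5 mL/min, between 0.3 mL/min and 6 mL/min, which means an estimated step of a 1.4-fold higher number from compound 1 to compound 4 (0.13 log units; within the scatter).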

Compound 4, intrinsic clearance in a liver preparation (reported as CLH), per the amount of preparation that the assay uses: 1 mL/min
Beside the measured number, compound 4's estimate is 1.5-fold (0.18 log units) above it; low and high end bracket the measured number.
By their numbers in this assay, from the lowest: compound 2; then compounds 4 and 1 (each within the scatter of the next); then compound 3.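

Placing 3,5-dichlorophenyl in place of 3,4-difluorophenyl on a sulfonyl sulfur gives, in this assay, a result that cannot be told apart from the starting compound (a 1.1-fold lower number from compound 1 to compound 4 (0.04 log units; within the scatter)). Among the compounds shown here, this is the first measured step at this position, and it is much smaller than the step seen on the other aromatic ring (a 110-fold lower number from compound 1 to compound 2 (2.04 log units; beyond the scatter)), so swapping these two halogenated phenyl groups leaves the clearance reading within the usual scatter. Nothing measured here offers a reason for this result.

Going by these compounds, it remains open whether a different kind of group on the sulfonyl sulfur, such as a phenyl ring carrying an amine or a carboxylic acid, or a longer alkyl chain, would move the number. On these data alone, it is also open whether 3,5-dichlorophenyl would give the same picture alongside the chloro group of compound 2.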